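This account rests on a few compounds, and the source may have more. Where it says the series, first, only, none or still open, it means among the compounds named here.

Measured in an ADME assay on microsomes from liver (Homo sapiens) for metabolic stability, read by LC-MS, using NADPH, with stated times of 5 min and 30 min, tested at 1 uM; a higher number here means that more of the compound is left, a lower number that less of the compound is left:
- compound 1 `COc1cccc(S(=O)(=O)/C=C/c2ccccn2)c1`: 74%
- compound 2 `COc1cccc(S(=O)(=O)/C=C/c2cccc(Cl)n2)c1`: 34%
- compound 3 `COc1cccc(S(=O)(=O)/C=C/c2ncccc2F)c1`: 31%

Compound 1 stands highest of these three. Compound 4 `COc1cccc(S(=O)(=O)/C=C/c2cccnc2)c1` has the same atoms as compound 1, joined differently: pyridin-3-yl in place of pyridin-2-yl on a double-bonded chain carbon bound to a double-bonded chain carbon. Among the compounds with values here, no measured step makes this exchange, so the evidence is indirect. Two large steps, both beyond the scatter, bear on it: chloro in place of hydrogen on an aromatic carbon gave a number 40 percentage points lower from compound 1 to compound 2 (beyond the scatter), and fluoro in place of hydrogen on an aromatic carbon gave a number 43 percentage points lower from compound 1 to compound 3 (beyond the scatter). On those two steps alone, a moderate fall in this assay is expected, smaller than either and uncertain in size. The expected change is a number 22 percentage points lower from compound 1 to compound 4 (beyond the scatter). Compound 4 is estimated at 52%, with an expected range of 28% to 78%.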

Compound 4, percent of the compound remaining: 75%
For compound 4 the middle estimate is 23 percentage points below the measured one; the measured number falls inside the stated range.
By their numbers in this assay, from the lowest: compounds 3 and 2 (each within the scatter of the next); then compounds 1 and 4 (each within the scatter of the next).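

In this assay, the exchange of pyridin-3-yl for pyridin-2-yl gave a number 1 percentage points higher from compound 1 to compound 4 (within the scatter) and so, unlike the chloro and fluoro steps, left the number within the scatter. At this place on the double-bonded chain carbon, the two pyridinyl attachments therefore cannot be told apart in this read-out, and the large falls seen earlier do not extend to this change. Nothing shown gives a cause for this result.

Going by these compounds, whether pyridin-4-yl or a phenyl ring would also hold the number in this assay stays open. So does whether chloro, fluoro or an amine on pyridin-3-yl would bring falls like those seen on pyridin-2-yl.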